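A Trifluoromethoxy Group on the Shared Core

The source may hold more compounds than are shown below. What is called first, only, known or untested is meant among the compounds shown, and "the series" means these compounds.

Compound 1 `Oc1ccccc1-c1cc(-c2ccc(F)cc2)cc(-c2ccccc2O)n1` is the reference. In a functional assay on T47D cells (Homo sapiens) for inhibition (a lower number here means a stronger inhibitor, a higher number a weaker inhibitor), compound 1 gives > 50000 nM, which is a limit of the assay rather than a number. Compound 2 `Oc1ccc(-c2cc(-c3ccc(F)cc3)cc(-c3ccccc3O)n2)cc1` carries a 4-hydroxyphenyl in place of a 2-hydroxyphenyl; in this assay compound 2 gives > 50000 nM, again only a limit. The step that the two limits leave unreadable from compound 1 to compound 2 therefore cannot be read. Compound 3 `Oc1ccccc1-c1cc(-c2ccccc2C(F)(F)F)cc(-c2ccccc2O)n1` carries a 2-(trifluoromethyl)phenyl in place of the 4-fluorophenyl, and in this assay compound 3 gives 22500 nM, a genuine number; this is an at least 2.2-fold lower number from compound 1 to compound 3 (0.34 log units; beyond the scatter). Compound 1 thus sits at the limit of > 50000 nM in this assay, at which 2 of the 3 values shown sit, and only compound 3 falls inside the measurable range.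

Compound 4 `Oc1ccccc1-c1cc(-c2ccc(OC(F)(F)F)cc2)cc(-c2ccccc2O)n1` differs from compound 1 by trifluoromethoxy in place of fluoro on an aromatic carbon. For the measured compounds named here, the only measured step that bears on it is the fluoro-to-trifluoromethyl exchange, an at least 2.2-fold lower number from compound 1 to compound 3 (0.34 log units; beyond the scatter), which was at least modest. A fluorinated group entering the same ring is expected to move compound 4 in the same direction, though perhaps less far: an at least 1.4-fold lower number from compound 1 to compound 4 (0.15 log units; that floor lies within the scatter) is the expected step. Compound 4 is therefore estimated at 35000 nM, with a range from 12000 nM to 50000 nM, and a fair chance that the assay again returns only a limit.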

Compound 4, half-maximal inhibitory concentration: > 50000 nM
Compound 4: only a limit was reported (the forecaster's own chance of this, stated with the estimate: 45%); middle value at least 1.4-fold (0.15 log units) from the limit.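

Compound 4, like compound 1, returns only a limit in this assay, so no step between them can be read: the limit of > 50000 nM in this assay, at which 3 of the 4 values shown sit.

The compounds shown leave open how far trifluoromethoxy in place of fluoro actually moves the inhibition, and whether any change other than that in compound 3 gives a measurable value.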